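Methylation of the pyrrolidine nitrogen in a styryl-benzyl ether series

A few compounds are considered here, and "the series" means these few. Any claim that something is new, unique, unknown or untested is made for them only; others in the source may bear on it.

Measured compounds in a functional assay on FL5.12 cells (Mus musculus) for cytotoxicity, read by flow cytometry, with a stated time of 48 h; on this read-out higher numbers stand for weaker inhibition and lower numbers for stronger inhibition:
compound 1, `CCCCCC/C=C/c1ccc(CO[C@@H]2CN[C@@H](CO)C2)cc1`: 1400 nM
compound 2, `CCCCCC/C=C/c1ccc(CO[C@H]2CN[C@H](CO)C2)cc1`: 2400 nM
compound 3, `CCCCCCCCCCCC/C=C/c1ccc(CO[C@H]2CN[C@H](CO)C2)cc1`: 7300 nM

Compound 2 stands second highest of the three numbers in this assay. Its nearest neighbour is compound 1, with a 1.7-fold higher number from compound 1 to compound 2 (0.23 log units; within the scatter); this pair differs only in the drawn configuration, as the fact that compounds 1 and 2 differ only in the configuration as drawn records. The furthest is compound 3, with a 3.0-fold higher number from compound 2 to compound 3 (0.48 log units; beyond the scatter), where hexyl replaces hydrogen on a saturated chain carbon.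

The unmeasured compound 4 is `CCCCCC/C=C/c1ccc(CO[C@H]2C[C@H](CO)N(C)C2)cc1`. Relative to compound 2 the change is a group of 8 heavy atoms (6 carbon, 1 nitrogen, 1 oxygen; one five-membered non-aromatic ring with 1 hetero atom) in place of a group of 7 heavy atoms (5 carbon, 1 nitrogen, 1 oxygen; one five-membered non-aromatic ring with 1 hetero atom), on an oxygen on a saturated carbon. Neither measured step concerns this position: one is a change of configuration alone and the other an extension of the alkenyl chain. Among the compounds with values here, there is therefore no direct precedent for the methylated nitrogen, and the expectation is a step from compound 2 to compound 4 of a 1.3-fold higher number from compound 2 to compound 4 (0.10 log units; within the scatter), not beyond the scatter. Compound 4 is estimated at 3000 nM, within 1000 nM to 9000 nM.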

Compound 4, half-maximal inhibitory concentration: 1900 nM
Estimate against measurement, compound 4: 1.6-fold (0.20 log units) above; low and high end bracket the measured number.
By their numbers in this assay, from the lowest: compounds 1, 4 and 2 (each within the scatter of the next); then compound 3.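

In this assay, methyl in place of hydrogen on the amine nitrogen in the ring leaves the number within the scatter, with a 1.4-fold higher number from compound 1 to compound 4 (0.13 log units; within the scatter). The comparison with compound 2 reads the same, with a 1.3-fold lower number from compound 2 to compound 4 (0.10 log units; within the scatter), so compound 4 cannot be told apart from either of two reference compounds that are themselves related by stereochemistry alone: the fact that compounds 1 and 2 differ only in the configuration as drawn. Among the steps shown, the position therefore accepts methyl with no readable change, whereas the chain extension gives a 3.0-fold higher number from compound 2 to compound 3 (0.48 log units; beyond the scatter), which is beyond the scatter.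

As far as these compounds go, whether ethyl, benzyl or acetyl on the ring nitrogen would leave the number just as undisturbed remains open. So does whether methyl there would behave the same way on the longer chain of compound 3.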